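A few compounds are considered here, and "the series" means these few. Any claim that something is new, unique, unknown or untested is made for them only; others in the source may bear on it.

Compound 3 `Brc1ccc(Cn2ccc3nc(-c4ccccc4)nc-3c2)cc1` carries a 4-bromophenyl on a saturated chain carbon bound to an aromatic nitrogen. For the measured compounds named here, in an ADME assay on MDBK cells (Bos taurus) for cytotoxicity (a lower number here means that less compound is tolerated, a higher number that more compound is tolerated), compound 3 gives 83000 nM, the only plain number among the three values shown. Compound 1 `Fc1cccc(F)c1Cn1ccc2nc(-c3ccccc3)nc-2c1` reaches a limit of this assay at > 100000 nM. Compound 2 `Cc1cccc(Cn2ccc3nc(-c4ccccc4)nc-3c2)c1` likewise reaches a limit at > 100000 nM. Compound 4 `CC(C)=CCn1ccc2nc(-c3ccccc3)nc-2c1` has not been measured; its change from compound 3 is 2-methylprop-1-en-1-yl in place of 4-bromophenyl on a saturated chain carbon bound to an aromatic nitrogen. The steps that touch this same place are an at least 1.2-fold lower number from compound 1 to compound 3 (0.08 log units; that floor lies within the scatter) and an at least 1.2-fold lower number from compound 2 to compound 3 (0.08 log units; that floor lies within the scatter), each a floor lying within the scatter, while a step that the two limits leave unreadable from compound 1 to compound 2 cannot be read, as both of its ends sit at the limit of > 100000 nM in this assay, at which 2 of the 3 values shown sit. Going by the values given here, every exchange at this place so far has left the number near that limit, so no step beyond the scatter is expected here. The expected step is a 1.2-fold higher number from compound 3 to compound 4 (0.08 log units; within the scatter). Compound 4 is therefore estimated at 100000 nM, within a range from 40000 nM to 300000 nM, with a fair chance that only a limit is reported again.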

Compound 4, half-maximal cytotoxic concentration: > 100000 nM
Compound 4 ended at the assay's limit; the forecaster's own chance of this, stated with the estimate: 55%; the middle value sits exactly at the limit.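

In this assay, the place on a saturated chain carbon bound to an aromatic nitrogen now also takes a group with no ring, as 2-methylprop-1-en-1-yl replaces 4-bromophenyl with an at least 1.2-fold higher number from compound 3 to compound 4 (0.08 log units; that floor lies within the scatter). Until now, only phenyl groups carrying a substituent had been seen here, so an aromatic ring at this place is not needed for the read-out to stay near the limit. The steps to compound 4 from compound 1 and from compound 2 cannot be read, which leaves these three compounds unranked in this assay: the limit of > 100000 nM in this assay, at which 3 of the 4 values shown sit.

Going by these compounds, whether an amine or a carboxylic acid at this place would bring a step beyond the scatter remains open. On these data alone, how the three compounds at the limit truly compare also remains unknown.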